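A few compounds are considered here, and "the series" means these few. Any claim that something is new, unique, unknown or untested is made for them only; others in the source may bear on it.

Measured so far in a functional assay on Jurkat cells (Homo sapiens) for inhibition; a lower number here means a stronger inhibitor, a higher number a weaker inhibitor:
- compound 1 `CC(C)[C@H](NC(=O)COc1cccc2ccccc12)C(=O)N[C@@H](CC(=O)O)C(=O)CSc1nccn1C`: > 200000 nM
- compound 2 `Cc1cc(C)nc(SCC(=O)[C@H](CC(=O)O)NC(=O)[C@@H](NC(=O)COc2cccc3ccccc23)C(C)C)n1`: > 200000 nM

Both values are limits of this assay, not numbers. Compound 1 gives only the limit > 200000 nM in this assay. Compound 2 likewise gives only the limit > 200000 nM in this assay. The step from compound 1 to compound 2 therefore cannot be read, a step that the two limits leave unreadable from compound 1 to compound 2, since both sit at the limit of > 200000 nM in this assay, at which 2 of the 2 values shown sit. Where compound 2 stands can thus be said only as a limit.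

Compound 3 `CC(C)[C@H](NC(=O)COc1cccc2ccccc12)C(=O)N[C@@H](CC(=O)O)C(=O)COc1cc(C(F)(F)F)ncn1` differs from compound 2 by (6-(trifluoromethyl)pyrimidin-4-yl)oxy in place of (4,6-dimethylpyrimidin-2-yl)sulfanyl on a saturated chain carbon bound to a carbonyl carbon. Among the measured compounds shown here, no measured step bears on this change: the sole step is unreadable from the two limits, and the measured compounds give no anchor inside the range of this assay. The expected step from compound 2 to compound 3 is therefore an at least 2.0-fold lower number from compound 2 to compound 3 (0.30 log units; that floor lies within the scatter), with no direction supported by the data. Compound 3 is estimated at 100000 nM in this assay, within 5000 nM to 200000 nM, with a substantial chance that again only a limit is reported.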

Compound 3, half-maximal inhibitory concentration: > 200000 nM
Compound 3 was reported as a limit; the forecaster's own chance of this, stated with the estimate: 55%; middle value at least 2.0-fold (0.30 log units) from the limit.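

In this assay compound 3 gives > 200000 nM, a limit and not a number. The steps from compound 1 and compound 2 to compound 3 cannot be read: the limit of > 200000 nM in this assay, at which 3 of the 3 values shown sit. The compounds shown leave open whether their sulfanyl and oxy groups differ at all in this assay.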